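This account rests on a few compounds, and the source may have more. Where it says the series, first, only, none or still open, it means among the compounds named here.

In a functional assay on HCT-116 cells (Homo sapiens) for inhibition, read by sulforhodamine B assay, with a stated time of 48 h, tested at 50 uM (a lower number here means less inhibition of growth, a higher number more inhibition of growth at the concentration tested), the measured compounds gave:
compound 1 `COc1cc2c(cc1CC=C(C)C)C(=O)C[C@@H](c1ccc(Oc3ccc(F)cc3)cc1)O2`: 29%
compound 2 `COc1cc2c(cc1CC=C(C)C)C(=O)C[C@@H](c1ccc(Oc3cccc([N+](=O)[O-])c3)cc1)O2`: 46%
compound 3 `C#CCOc1ccc([C@@H]2CC(=O)c3cc(CC=C(C)C)c(OC)cc3O2)cc1`: 75%

Compound 3 stands highest of the three, with compound 2 nearest and compound 1 furthest, both gaps beyond the scatter. The three differ only in the group attached to an oxygen on an aromatic ring of the shared core: a 4-fluorophenyl in compound 1, a 3-nitrophenyl in compound 2 and a propargyl in compound 3. Those exchanges gave a number 17 percentage points higher from compound 1 to compound 2 (beyond the scatter), a number 29 percentage points higher from compound 2 to compound 3 (beyond the scatter) and a number 46 percentage points higher from compound 1 to compound 3 (beyond the scatter).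

Compound 4 `CCCOc1ccc([C@@H]2CC(=O)c3cc(CC=C(C)C)c(OC)cc3O2)cc1` keeps the short chain of compound 3 but loses its triple bond: ethyl in place of ethynyl on a saturated chain carbon bound to an oxygen on an aromatic ring. Going by the values given here, none of the measured steps bears directly on this. Each of them replaces one whole group on the aromatic oxygen with another, and none keeps a short chain while changing only the bonds within it. What the numbers do show is that the chain-bearing compound 3 sits well above both aryl-bearing compounds, and compound 4 stays with a chain rather than returning to an aryl group. A step smaller than those shown, most likely downward, is therefore expected in this assay. For compound 4 the expected step is a number 17 percentage points lower from compound 3 to compound 4 (beyond the scatter). Compound 4 is estimated at 58%, within a range of 35% to 80% in this assay.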

Compound 4, percent growth inhibition at one concentration: 63%
Estimate against measurement, compound 4: 5 percentage points below; low and high end bracket the measured number.
By their numbers in this assay, from the lowest: compound 1; then compound 2; then compound 4; then compound 3.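

In this assay, exchanging only the triple bond of the propargyl group for the saturated propyl group gives a number 12 percentage points lower from compound 3 to compound 4 (beyond the scatter), so changing the bonds within this short chain on the aromatic oxygen, with no change in its count of heavy atoms, is enough to move the number. The saturated chain still stands above both aryl groups, with a number 17 percentage points higher from compound 2 to compound 4 (beyond the scatter) and a number 34 percentage points higher from compound 1 to compound 4 (beyond the scatter), so among these four compounds a short chain on this oxygen gives the higher numbers with or without the triple bond. No measurement available here explains why either kind of exchange changes growth inhibition.

The compounds shown leave open how chain length matters, since a shorter methyl group or a longer butyl or hexyl chain on the same oxygen would show whether propargyl and propyl lie near a limit of what this position accepts. They also leave open whether the chain tolerates an added group, such as an amine or a carboxylic acid at its far end, and how such a chain would compare with compound 3 in this assay.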